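The source may hold more compounds than are shown below. What is called first, only, known or untested is meant among the compounds shown, and "the series" means these compounds.

Measured so far in an assay on mitochondria from L6 cells (Rattus norvegicus) for activation, with a stated time of 90 min; a higher number here means that more compound is needed for the effect, a lower number that less compound is needed:
- compound 1 `Fc1ccccc1Nc1nc2nonc2nc1Nc1ccccc1`: 2200 nM
- compound 2 `Cc1cccc(Nc2nc3nonc3nc2Nc2ccccc2F)c1`: 1500 nM

Compound 1 stands alongside compound 2 in this assay, since the step of a 1.5-fold lower number from compound 1 to compound 2 (0.17 log units; within the scatter) does not separate them. Compound 3 `Fc1ccccc1Nc1nc2nonc2nc1Nc1ccccc1C(F)(F)F` differs from compound 1 by trifluoromethyl in place of hydrogen on an aromatic carbon. Among the compounds with values here, the only measured step, from compound 1 to compound 2, concerns a methyl on the other aryl ring, not this position, and it stayed within the scatter; no measured step tests a trifluoromethyl. The expectation for compound 3 is therefore a step of a 1.4-fold lower number from compound 1 to compound 3 (0.14 log units; within the scatter), not beyond the scatter. Compound 3 is estimated at 1600 nM, with a range from 500 nM to 5000 nM.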

Compound 3, half-maximal effective concentration: 1400 nM
Compound 3: middle estimate off by 1.1-fold (0.06 log units), on the high side, within the range that was stated.
By their numbers in this assay, from the lowest: compounds 3, 2 and 1 (each within the scatter of the next).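

Trifluoromethyl in place of hydrogen on an aromatic carbon, ortho to a large group, gives the first reading at this place in this assay, with a 1.6-fold lower number from compound 1 to compound 3 (0.20 log units; within the scatter). The shared core therefore accepts this larger group here without a step beyond the scatter, which the methyl change on the other aryl ring could not show. Nothing available accounts for this reading.

Still open, as far as these compounds go, is whether an amine or a carboxylic acid at this place would give a step beyond the scatter. Also open, from the compounds shown here alone, is whether trifluoromethyl and methyl together on the shared core would do so.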